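The source may hold more compounds than are shown below. What is called first, only, known or untested is meant among the compounds shown, and "the series" means these compounds.

The series shares one core, carried by compound 1 `CCOC(=O)c1sc(-c2cccc(NC(=O)c3ccc(F)cc3)c2)nc1Nc1ccc(N2CCN(C)CC2)cc1`, compound 2 `CCOC(=O)c1sc(-c2cccc(NC(=O)c3ccc(C(C)(C)C)cc3)c2)nc1Nc1ccc(N2CCN(C)CC2)cc1`, compound 3 `CCOC(=O)c1sc(-c2cccc(NC(=O)c3ccccc3)c2)nc1Nc1ccc(N2CCN(C)CC2)cc1` and the unmeasured compound 4 `CCOC(=O)c1sc(-c2cccc(NC(=O)c3ccc(C#N)cc3)c2)nc1Nc1ccc(N2CCN(C)CC2)cc1`. In a functional assay on Ramos cells (Homo sapiens) for antiproliferative activity, read by CCK-8 assay, with a stated time of 72 h (a lower number here means a stronger inhibitor, a higher number a weaker inhibitor), compound 3 gives 24800 nM, a weak result. Compound 2 stands without a number in this assay, as its entry reads "not determined" (no result reported), and compound 1 likewise carries "not determined" (no result reported), so compound 3 is the only anchor the series offers.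

The step from compound 2 to compound 4 is cyano in place of tert-butyl on an aromatic carbon of a six-membered aromatic ring of carbon only, para to a large group. For the measured compounds named here, no step between measured compounds is available to calibrate this change, and compound 2 itself has no number to step from. Going by the values given here, what can be said is that the one measured member, compound 3, sits far toward the weak end of this assay, and a single change on the outer aromatic ring is not expected to move compound 4 far from that region; any shift in either direction would likely fall within or only modestly beyond the usual scatter.

Compound 4 is therefore expected to give about 20000 nM in this assay, with a plausible range from 5000 nM to 60000 nM.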

Compound 4, half-maximal inhibitory concentration: 4280 nM
Beside the measured number, compound 4's estimate is 4.7-fold (0.67 log units) above it, outside the stated range (below it).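

In this assay, cyano in place of hydrogen on an aromatic carbon, para to a large group, gives a 5.8-fold lower number from compound 3 to compound 4 (0.76 log units; beyond the scatter), a modest step but one beyond the scatter. With compound 3 as the only earlier number, the series had shown nothing about this position; this is the first sign that a single change there can move the result, and that it can do so toward a stronger inhibitor. The steps that would involve compound 1 and compound 2 cannot be read, so the change from tert-butyl to cyano remains uncalibrated, and no measured property of these compounds bears on the step from hydrogen to cyano.

The compounds shown leave open whether this gain belongs to cyano in particular or would also appear with another group at the same place, such as an amine, a carboxylic acid or a methoxy group. They also leave open whether a step of this size would hold on a different core, as both measured compounds carry the same one and a single pair cannot establish a trend.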